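Ortho group swap on the cyclohexanedione series

The compounds below may be only part of what the source reports. "The series", "measured", "known", "first", "only" and "open" are said of these compounds alone.

Compound 1 `Cc1ccccc1C(=O)C1C(=O)CCCC1=O` gives 3750 nM in an assay for inhibition of 4-hydroxyphenylpyruvate dioxygenase (Sus scrofa); on this read-out lower numbers stand for stronger inhibition and higher numbers for weaker inhibition.
Compound 2 `O=C1CCCC(=O)C1C(=O)c1ccccc1C(F)(F)F` gives 250 nM in this assay.

In this assay compound 2 stands lowest of the two numbers; the nearest is compound 1, a step of a 15-fold lower number from compound 1 to compound 2 (1.18 log units; beyond the scatter). That single step shows the group at this place moves the number strongly. Compound 3 `O=C1CCCC(=O)C1C(=O)c1ccccc1Cl` carries chloro in place of trifluoromethyl on an aromatic carbon. Among the compounds with values here, no measured pair sets chloro against trifluoromethyl, so direction rests only on that one step. Compound 3 is expected at 600 nM (200 nM to 2000 nM). The expected step is a 2.4-fold higher number from compound 2 to compound 3 (0.38 log units; beyond the scatter), toward a higher number, modest and possibly within the scatter.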

Compound 3, half-maximal inhibitory concentration: 500 nM
Beside the measured number, compound 3's estimate is 1.2-fold (0.08 log units) above it; measured number inside the range.
By their numbers in this assay, from the lowest: compounds 2 and 3 (each within the scatter of the next); then compound 1.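

In this assay, chloro in place of trifluoromethyl on the aromatic carbon leaves the two compounds within the scatter of each other (a 2.0-fold higher number from compound 2 to compound 3 (0.30 log units; within the scatter)). Chloro in place of methyl gives a clear step (a 7.5-fold lower number from compound 1 to compound 3 (0.88 log units; beyond the scatter)), so the separation from compound 1 is not tied to trifluoromethyl alone. No supporting measurement speaks to the cause of these steps.

Still open, as far as these compounds go, is how other groups at this place compare, such as a nitrile, a methoxy group or an amine. From the compounds shown here alone, whether any of them would stand apart from both compound 2 and compound 3 also remains open.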